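From Methoxy to Hydroxy on Compound 2

This account rests on a few compounds, and the source may have more. Where it says the series, first, only, none or still open, it means among the compounds named here.

In an ADME assay on HEK293 cells (Homo sapiens) for cytotoxicity, read by CellTiter-Glo and resazurin assay, with a stated time of 72 h (a lower number here means that less compound is needed, a higher number that more compound is needed for the effect), compound 2 (`COc1cccc(-c2ccc(C(=O)N(Cc3cccc(OCCCCCC(=O)O)c3)C(C)C)cc2)c1`) gives > 20900 nM as a limit and not a number. Compound 1 (`CC(C)N(Cc1cccc(OCCCCCC(=O)O)c1)C(=O)c1ccc(-c2cccc3ccccc23)cc1`) gives > 26000 nM as a limit too. Compound 3 (`CC(C)N(Cc1cccc(OCCCCCC(=O)O)c1)C(=O)c1ccc(-c2cccc(O)c2)cc1`) differs from compound 2 by one change (hydrogen in place of methyl on an oxygen on an aromatic ring) with hydrogen in place of methyl on an oxygen on an aromatic ring, so that 3-methoxyphenyl becomes 3-hydroxyphenyl. Among the measured compounds shown here, the only measured step that bears on this is a step that the two limits leave unreadable from compound 1 to compound 2 and it changes the same aromatic group. That step has no readable size, so it offers no sign of a large move in either direction. The expected change is a step that the limit leaves unreadable from compound 2 to compound 3 and nothing beyond the usual scatter. Compound 3 is estimated at 24000 nM with an expected range from 12000 nM to 50000 nM and will probably be reported only as a limit.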

Compound 3, half-maximal effective concentration: > 26000 nM
Compound 3 ended at the assay's limit; the forecaster's own chance of this, stated with the estimate: 85%; middle value at least 1.0-fold (0.03 log units) away from the limit.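

Among the compounds shown here, compound 1, compound 2 and compound 3 each give only a limit and not a number, and no step among the three can be read. The compounds shown leave open whether naphthalen-1-yl, 3-methoxyphenyl and 3-hydroxyphenyl differ at all in their effect on these cells.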